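Removing one methyl from compound 1

This account rests on a few compounds, and the source may have more. Where it says the series, first, only, none or still open, it means among the compounds named here.

Measured in an ADME assay on cells (Fibroblast, Homo sapiens) for cytotoxicity, with a stated time of 48 h; a higher number here means a weaker inhibitor, a lower number a stronger inhibitor:
- compound 1 `COc1cc(OC)c(C(=O)/C=C/c2ccccc2OC)c(OC)c1`: 8200 nM
- compound 2 `COc1cc(OC)c(C(=O)/C=C/c2ccccc2SC)c(OC)c1`: > 20000 nM (a limit)
- compound 3 `COc1cc(OC)c(C(=O)/C=C/c2ccccc2)c(OC)c1`: > 20000 nM (a limit)

Only compound 1 has a true number in this assay, at 8200 nM. The other two compounds sit at the limit of > 20000 nM in this assay, at which 2 of the 3 values shown sit.

The next compound, compound 4 `COc1cc(O)c(C(=O)/C=C/c2ccccc2OC)c(OC)c1`, changes compound 1 in one place: hydrogen in place of methyl on an oxygen on an aromatic ring. This is hydrogen in place of methyl on an oxygen on an aromatic ring, so a methoxy becomes a hydroxy.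

Going by the values given here, no measured step makes this exact change, so the evidence is indirect. Two steps alter a methoxy on an aromatic carbon of compound 1. Methylsulfanyl in its place gives an at least 2.4-fold higher number from compound 1 to compound 2 (0.38 log units; beyond the scatter). Hydrogen in its place gives an at least 2.4-fold higher number from compound 1 to compound 3 (0.38 log units; beyond the scatter). Both steps run toward higher numbers, but each is known only as a minimum size, and both end at a limit. Neither replaces a methyl on an oxygen, and compound 4 keeps its oxygen, so they offer only a weak lean upward. The expected result is a 1.3-fold higher number from compound 1 to compound 4 (0.13 log units; within the scatter), a shift not expected to exceed the scatter. For compound 4 the estimated value is 11000 nM, with an expected range from 4500 nM to 20000 nM.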

Compound 4, half-maximal inhibitory concentration: > 20000 nM
Compound 4: no number, only a limit (the forecaster's own chance of this, stated with the estimate: 35%); middle value at least 1.8-fold (0.25 log units) from the limit.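

In this assay, hydrogen in place of methyl on an oxygen on an aromatic ring gives an at least 2.4-fold higher number from compound 1 to compound 4 (0.38 log units; beyond the scatter), so losing the methyl alone is enough for this step, even though the oxygen stays. The methoxy changed here is a different one from the methoxy altered in compound 2 and compound 3, so single changes at two separate methoxy groups of compound 1 now run in the same direction. Compound 1 remains the only compound with a true number, and the other three all end at one limit: the limit of > 20000 nM in this assay, at which 3 of the 4 values shown sit.

From the compounds shown here alone, the steps among the compounds at that limit cannot be read, and the true size of each step from compound 1 stays unknown beyond its stated minimum. Going by these compounds, it also remains open whether a longer chain on this oxygen, such as ethoxy, or an amine in place of the methoxy would keep a true number in this assay.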